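The compounds below may be only part of what the source reports. "The series", "measured", "known", "first", "only" and "open" are said of these compounds alone.

Measured so far:
compound 1, `O=C([C@@H]1CCCN(S(=O)(=O)c2ccc(S(=O)(=O)C3COC3)cc2)C1)N1CCC(F)(F)CC1`, 361 nM
compound 2, `O=C([C@@H]1CCCN(S(=O)(=O)c2ccc(S(=O)(=O)C3CC3)cc2)C1)N1CCC(F)(F)CC1`, 129 nM
compound 3, `CCN(CC)S(=O)(=O)c1ccc(S(=O)(=O)N2CCC[C@@H](C(=O)N[C@H]3CCOC3)C2)cc1`, 5270 nM

In a functional assay on BXPC-3 cells (Homo sapiens) for inhibition, read by MTT assay, with a stated time of 7 days (a higher number here means a weaker inhibitor, a lower number a stronger inhibitor), compound 3 gives the highest of the three numbers; the nearest measured compound is compound 1, which gives 361 nM, and the furthest is compound 2, which gives 129 nM, both gaps beyond the scatter. Within the data shown here, the one step measured between neighbours, a 2.8-fold lower number from compound 1 to compound 2 (0.45 log units; beyond the scatter), sits on a sulfonyl sulfur and does not touch the amide; it therefore says nothing direct about the change in hand.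

Compound 4, `CCN(CC)S(=O)(=O)c1ccc(S(=O)(=O)N2CCC[C@@H](C(=O)N3CCC(C(F)F)CC3)C2)cc1`, is not yet measured. It differs from compound 3 at the carbonyl carbon: 4-(difluoromethyl)piperidin-1-yl in place of (oxolan-3-yl)amino on a carbonyl carbon. Among the measured compounds shown here, this brings the amide of compound 4 closer in kind to the amide seen in compound 1 and compound 2, whose structures stand above, though compound 4 keeps the diethylsulfamoyl part of compound 3, so no measured pair isolates this change. Given that compound 1 and compound 2 both lie well below compound 3 in this assay, the expectation is a step down, a 7.5-fold lower number from compound 3 to compound 4 (0.88 log units; beyond the scatter), with wide uncertainty. Compound 4 is estimated at 700 nM in this assay, in the range 150 nM to 3000 nM.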

Compound 4, half-maximal inhibitory concentration: 450 nM
Beside the measured number, compound 4's estimate is 1.6-fold (0.19 log units) above it; the measured number falls inside the stated range.
By their numbers in this assay, from the lowest: compound 2; then compounds 1 and 4 (each within the scatter of the next); then compound 3.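

In this assay, the position on the carbonyl carbon proves strongly responsive, with a 12-fold lower number from compound 3 to compound 4 (1.07 log units; beyond the scatter) on placing 4-(difluoromethyl)piperidin-1-yl where (oxolan-3-yl)amino stood, while the diethylsulfamoyl part stays fixed. Among these compounds, this is the first measured step at this position, and it is larger than the only earlier one, which lay on a sulfonyl sulfur. The step cannot be assigned to any single feature, since the entering group differs at once in ring size, in heavy atoms, in fluorine content and in having no hydrogen-bond donor or acceptor, and nothing at hand offers a reason for its size.

The compounds shown do not separate these features: a plain piperidin-1-yl would isolate the contribution of the difluoromethyl group, and an (oxolan-3-yl)amino carrying a methyl on its nitrogen would test the loss of the amide hydrogen with the oxolane ring retained. Also open, going by these compounds, is whether the gain at this position carries over unchanged when the diethylsulfamoyl part gives way to another sulfonyl group, such as the cyclopropylsulfonyl of the shared core of compound 2.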